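A few compounds are considered here, and "the series" means these few. Any claim that something is new, unique, unknown or untested is made for them only; others in the source may bear on it.

Measured in an ADME assay on a cell-free system (serum) for metabolic stability; on this read-out lower numbers stand for a shorter-lived compound and higher numbers for a longer-lived compound:

- Compound 1 `CC(C)(C)c1cc(OC(=O)c2ccco2)ccc1O`: < 0.25 h
- Compound 2 `COc1ccccc1C(=O)Oc1ccc(O)c(C(C)(C)C)c1`: < 0.25 h
- Compound 3 `CC(C)(C)c1cc(OC(=O)c2c(Cl)cc([N+](=O)[O-])cc2Cl)ccc1O`: < 0.25 h

Compound 1 stands at < 0.25 h, which is a limit of the assay and not a number. As far as these compounds go, the same holds for compound 2 and compound 3, so the true half-lives of all three remain unknown, and nothing separates compound 1 from the other two. The whole picture comes down to the limit of < 0.25 h in this assay, at which 3 of the 3 values shown sit.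

The next compound, compound 4 `CC(C)(C)c1cc(OC(=O)c2ccc(N)cc2)ccc1O`, keeps the core of compound 1 but carries 4-aminophenyl in place of furan-2-yl on a carbonyl carbon. Among the compounds with values here, no two measured compounds differ in just one place, so the data give no measured step size to borrow. The three measured compounds have quite different groups at this place, yet all share (the limit of < 0.25 h in this assay, at which 3 of the 3 values shown sit), so no large step is expected in this assay, and no step in either direction beyond the usual scatter. The estimated change a number no lower from compound 1 to compound 4 (the limit leaves the size open) is therefore small. Compound 4 is expected to give a half-life of about 0.25 h. The expected range for compound 4 runs from 0.1 h to 1 h.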

Compound 4, half-life: < 0.25 h
Compound 4 was reported as a limit (the forecaster's own chance of this, stated with the estimate: 60%); the middle value lies on the limit itself.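

Within the data shown here, compound 1 and compound 4 are both reported as limits of the assay and not as numbers, so no step between them can be read. The true half-life of each compound shown stays open, as does whether the group on the carbonyl carbon changes it in this assay, because all the results share one limit: the limit of < 0.25 h in this assay, at which 4 of the 4 values shown sit.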